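Thiophen-3-yl in Place of Iodo on a Nucleoside Core

The source may hold more compounds than are shown below. What is called first, only, known or untested is meant among the compounds shown, and "the series" means these compounds.

Compound 1 `COc1ncnc2c1c(I)cn2[C@@H]1O[C@H](CO)[C@@H](O)[C@H]1O` carries an iodo group on its core. In a functional assay on HCT-116 cells (Homo sapiens), read by MTT assay, with a stated time of 72 h (on this read-out higher numbers stand for weaker inhibition and lower numbers for stronger inhibition), compound 1 gives > 20000 nM, which is a limit of the assay and not a number. Compound 2 `CNc1ncnc2c1c(-c1ccccc1)cn2[C@@H]1O[C@H](CO)[C@@H](O)[C@H]1O` likewise gives > 20000 nM in this assay, again only a limit. Compound 3 `O=c1[nH]cnc2c1c(-c1cccs1)cn2[C@@H]1O[C@H](CO)[C@@H](O)[C@H]1O` gives > 20000 nM in this assay, also a limit. Every value shown therefore sits at the limit of > 20000 nM in this assay, at which 3 of the 3 values shown sit, so compound 1 stands nowhere above or below its companions. Compound 4 `COc1ncnc2c1c(-c1ccsc1)cn2[C@@H]1O[C@H](CO)[C@@H](O)[C@H]1O` differs from compound 1 by thiophen-3-yl in place of iodo on an aromatic carbon. For the measured compounds named here, with no measured step available, no shift beyond the scatter is expected in this assay. The step from compound 1 to compound 4 is estimated as a step that the limit leaves unreadable from compound 1 to compound 4. Compound 4 is expected to give 30000 nM, within 10000 nM to 100000 nM, most likely reported once more as a limit.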

Compound 4, half-maximal inhibitory concentration: 120 nM
Compound 4: the middle estimate sits 250-fold (2.40 log units) above what was measured; the measured number lies below the stated range.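

On the shared core, this aromatic carbon proves decisive in this assay: thiophen-3-yl in place of iodo gives an at least 160-fold lower number from compound 1 to compound 4 (2.22 log units; beyond the scatter). For the compounds shown here, compound 4 is the first compound here with a measured number and not a limit, so a single change at this position is enough to bring activity into readable range. The step gives only a minimum size, because compound 1 holds only a limit: the limit of > 20000 nM in this assay, at which 3 of the 4 values shown sit.

On these data alone, whether the sulfur of the thiophen-3-yl matters remains open, since one replacement cannot separate the ring from its hetero atom. As far as these compounds go, how furan-3-yl, an amine or a carboxylic acid at this carbon would read also remains unknown.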